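Thiazole for pyridine on the cyclopropane of compound 2

The source may hold more compounds than are shown below. What is called first, only, known or untested is meant among the compounds shown, and "the series" means these compounds.

Compound 2 `CC[C@H](C)[C@H](N)CN(C(=O)[C@@H]1C[C@H]1c1ccncc1)c1ccc(-c2ccccc2)cc1` stands at the lower of the two numbers in a functional assay for agonist activity at G protein-coupled receptor 88 (Homo sapiens), read by HTRF and cAMP accumulation (a lower number here means that less compound is needed, a higher number that more compound is needed for the effect), and gives 1500 nM; compound 1 `CC[C@H](C)[C@H](N)CN(C(=O)[C@@H]1C[C@H]1c1cccc(OC)c1)c1ccc(-c2ccccc2)cc1` gives 3000 nM, and the gap, a 2.0-fold lower number from compound 1 to compound 2 (0.30 log units; within the scatter), is within the scatter. Compound 3 `CC[C@H](C)[C@H](N)CN(C(=O)[C@@H]1C[C@H]1c1nc(C)c(C)s1)c1ccc(-c2ccccc2)cc1` differs from compound 2 by 4,5-dimethyl-1,3-thiazol-2-yl in place of pyridin-4-yl on a saturated ring carbon. For the measured compounds named here, the only measured step at this carbon, a 2.0-fold lower number from compound 1 to compound 2 (0.30 log units; within the scatter), stayed within the scatter, so the series gives no sign that an aromatic exchange here moves the number. For compound 3 the expected step is therefore no change at the digits printed from compound 2 to compound 3 (within the scatter), none beyond the scatter. Compound 3 is estimated at 1500 nM, with a range of 600 nM to 4000 nM.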

Compound 3, half-maximal effective concentration: 3600 nM
Compound 3: middle estimate off by 2.4-fold (0.38 log units), on the low side; low and high end bracket the measured number.
By their numbers in this assay, from the lowest: compounds 2, 1 and 3 (each within the scatter of the next, the first and the last beyond it).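

For the compounds shown here, on this saturated ring carbon, this assay now gives a first aromatic exchange beyond the scatter, though a modest one, with a 2.4-fold higher number from compound 2 to compound 3 (0.38 log units; beyond the scatter) for 4,5-dimethyl-1,3-thiazol-2-yl in place of pyridin-4-yl. The same group in place of 3-methoxyphenyl stays within the scatter, with a 1.2-fold higher number from compound 1 to compound 3 (0.08 log units; within the scatter), so the change depends on which aromatic group leaves. Nothing available explains the step. Open, from the compounds shown here alone, is whether the thiazole ring or its two methyl groups carry the step. An unsubstituted 1,3-thiazol-2-yl or a pyridin-4-yl bearing an amine would test this position further.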